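Adding one hydroxy group to compound 3

This account rests on a few compounds, and the source may have more. Where it says the series, first, only, none or still open, it means among the compounds named here.

Measured so far in a functional assay on HL-60 cells (Homo sapiens) for cytotoxicity, read by WST assay, with a stated time of 48 h; a higher number here means that more compound is needed for the effect, a lower number that less compound is needed:
- compound 1 `O=C1OC[C@H](Cc2ccccc2O)[C@H]1Cc1ccc(Cl)c(Cl)c1` gives 33000 nM
- compound 2 `O=C1OC[C@H](Cc2cccc(O)c2)[C@H]1Cc1ccc(Cl)c(Cl)c1` gives 48000 nM
- compound 3 `COc1ccc(C[C@H]2COC(=O)[C@@H]2Cc2ccc(Cl)c(Cl)c2)cc1` gives 37000 nM

These three compounds share one core and differ only in the group on one of their two aromatic rings. Compound 3, at 37000 nM in this assay, cannot be ranked against the other two, since its value lies within the usual scatter of both.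

The next compound, compound 4 `COc1ccc(C[C@H]2COC(=O)[C@@H]2Cc2ccc(Cl)c(Cl)c2)cc1O`, carries hydroxy in place of hydrogen on an aromatic carbon, ortho to a methoxy group and meta to a large group hydroxy in place of hydrogen on an aromatic carbon in comparison with compound 3.

Three measured steps offer guidance. The change to 3-hydroxyphenyl from 2-hydroxyphenyl gave a 1.5-fold higher number from compound 1 to compound 2 (0.16 log units; within the scatter) here. The change to 4-methoxyphenyl from 2-hydroxyphenyl gave a 1.1-fold higher number from compound 1 to compound 3 (0.05 log units; within the scatter) here, and the change to 4-methoxyphenyl from 3-hydroxyphenyl gave a 1.3-fold lower number from compound 2 to compound 3 (0.11 log units; within the scatter) here. None of these steps puts both a hydroxy and a methoxy on one ring, so the guidance is indirect. Since all three stayed small, no shift beyond the scatter is expected in either direction.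

The expected change is a 1.2-fold lower number from compound 3 to compound 4 (0.06 log units; within the scatter) as an estimate. The estimated value for compound 4 is 32000 nM, with an expected range from 13000 nM to 65000 nM as its limits of estimate.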

Compound 4, half-maximal effective concentration: 32000 nM
For compound 4 middle estimate and measured number coincide at the digits printed, within the range that was stated.
By their numbers in this assay, from the lowest: compounds 4, 1, 3 and 2 (each within the scatter of the next).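

In this assay, hydroxy in place of hydrogen on an aromatic carbon, ortho to a methoxy group and meta to a large group, gives a 1.2-fold lower number from compound 3 to compound 4 (0.06 log units; within the scatter). Among these compounds, compound 4 is the first compound here with both a hydroxy and a methoxy group on one ring, so the same ring can also be read from the hydroxy side, where adding a methoxy group gives a 1.5-fold lower number from compound 2 to compound 4 (0.18 log units; within the scatter). Adding either group to a ring that already holds the other thus leaves the number within the scatter, and no available evidence accounts for this lack of a measurable shift.

Going by these compounds, whether an amine, a carboxylic acid or a longer chain in place of the hydroxy group on this ring would give a step beyond the scatter remains open. Also open, on these data alone, is whether changes to the other aromatic ring or to the shared core would shift the number in this assay further than these changes on this ring have done.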